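Swapping a dichlorobenzyl for a fluorobenzyl on a shared core

The compounds below may be only part of what the source reports. "The series", "measured", "known", "first", "only" and "open" are said of these compounds alone.

Of the compounds shown here, three built on one shared core have been tested in a functional assay on UACC-257 cells (Homo sapiens) for inhibition, read by sulforhodamine B assay, with a stated time of 48 h; on this read-out higher numbers stand for weaker inhibition of growth and lower numbers for stronger inhibition of growth. Compound 1 `Nc1cc(N)c2nc(-c3ccccc3)c(NCc3ccc(Cl)c(Cl)c3)nc2c1` gives 15800 nM, the second highest of the three numbers. Compound 2 `COc1cc(CNc2nc3cc(N)cc(N)c3nc2-c2ccccc2)cc(OC)c1OC` gives 10700 nM, a number that lies within the usual scatter of that of compound 1, so the two cannot be told apart. Compound 3 `CCOC(=O)[C@H](CCC(=O)O)NC(=O)c1ccc(Oc2nc3cc(N)cc(N)c3nc2-c2ccccc2)cc1` gives 55000 nM, a gap from compound 1 that lies beyond the scatter, so compound 3 inhibits growth less strongly.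

Compound 4 `Nc1cc(N)c2nc(-c3ccccc3)c(NCc3ccc(F)cc3)nc2c1` has not been measured. It differs from compound 1 in one place: 4-fluorophenyl in place of 3,4-dichlorophenyl on a saturated chain carbon bound to a nitrogen on an aromatic ring. Among the measured compounds shown here, no measured pair shows a change of this kind, so the step can only be guessed. For compound 4 the expected step of a 1.4-fold higher number from compound 1 to compound 4 (0.14 log units; within the scatter) is small, toward a somewhat higher number, hardly beyond the scatter. Compound 4 is therefore estimated at 22000 nM, with a range from 9000 nM to 55000 nM.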

Compound 4, concentration for total growth inhibition: 4270 nM
The estimate for compound 4 lay 5.2-fold (0.71 log units) above the measured number; the whole stated range lies above it.
By their numbers in this assay, from the lowest: compound 4; then compounds 2 and 1 (each within the scatter of the next); then compound 3.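

In this assay, exchanging 3,4-dichlorobenzyl for 4-fluorobenzyl gives a 3.7-fold lower number from compound 1 to compound 4 (0.57 log units; beyond the scatter). Among the compounds shown here, this is the first comparison here of compounds that differ in one place, and it shows that the substituents on this phenyl ring alone can strengthen growth inhibition beyond the scatter. Nothing available gives a reason for this step.

From the compounds shown here alone, it remains open whether the gain follows the fluorine or the loss of the chlorines: a plain benzyl or a 4-chlorobenzyl group would separate the two. Going by these compounds, how a longer chain carrying the same 4-fluorophenyl would behave is also open.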